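A few compounds are considered here, and "the series" means these few. Any claim that something is new, unique, unknown or untested is made for them only; others in the source may bear on it.

For the measured compounds named here, compound 2 `COc1ccc(C2=NN(C(=O)c3cccnc3Cl)C(c3ccc(Br)cc3)C2)cc1` gives 3050 nM in a functional assay on WM 266-4 cells (Homo sapiens) for antiproliferative activity, read by MTT assay, with a stated time of 24 h (a lower number here means a stronger inhibitor of growth, a higher number a weaker inhibitor of growth), and stands lowest of the two numbers known so far. Compound 1 `COc1ccc(C2=NN(C(=O)c3ccc(Cl)nc3)C(c3ccc(Br)cc3)C2)cc1` gives 7130 nM. Going by the values given here, the only measured step, a 2.3-fold lower number from compound 1 to compound 2 (0.37 log units; beyond the scatter), concerns a different part of the molecule. Compound 3 `COc1ccc(C2=NN(C(=O)c3cccnc3Cl)C(c3ccc(OCc4ccccc4)cc3)C2)cc1` differs from compound 2 elsewhere: benzyloxy in place of bromo on an aromatic carbon. Among the compounds with values here, no measured pair speaks to this change, so the best guide is simply where compound 2 already stands. Compound 3 is therefore expected to come out near compound 2, with a 1.2-fold lower number from compound 2 to compound 3 (0.09 log units; within the scatter), at an estimated 2500 nM in this assay, plausibly anywhere from 800 nM to 8000 nM.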

Compound 3, concentration for 50% growth inhibition: 9150 nM
Compound 3: middle estimate off by 3.7-fold (0.56 log units), on the low side; the whole stated range lies below it.
By their numbers in this assay, from the lowest: compound 2; then compounds 1 and 3 (each within the scatter of the next).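

Replacing bromo with the much larger benzyloxy, para to a large group, gives a 3.0-fold higher number from compound 2 to compound 3 (0.48 log units; beyond the scatter) in this assay and so weaker growth inhibition. For the compounds shown here, this is the first measured change at this position, and it shows that adding a second aromatic ring and an oxygen here brings no gain, though compound 3 still inhibits growth. Nothing available explains the loss.

From the compounds shown here alone, whether a small fluoro, an amine or a carboxylic acid would do better here remains open. So does whether the loss comes from the added ring or from the oxygen linking it.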